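Hydroxy on the triazole side chain: compound 4 expected

The source may hold more compounds than are shown below. What is called first, only, known or untested is meant among the compounds shown, and "the series" means these compounds.

Compound 1 `CC(C)n1cnnc1-c1cccc(NC(=O)Nc2cnc3ccccc3n2)n1` and compound 2 `CC(C)n1cnnc1-c1cccc(NC(=O)Nc2ncc3ccccc3n2)n1` contain the same atoms joined differently; the difference between the two cores is not broken down here. In an assay on isolated protein for inhibition of mitogen-activated protein kinase kinase kinase 6 (Homo sapiens) (on this read-out lower numbers stand for stronger inhibition and higher numbers for weaker inhibition), compound 1 gives 4860 nM. Compound 2 gives 2910 nM in this assay, a value within the scatter of that of compound 1. Compound 3 `C[C@H](CO)n1cnnc1-c1cccc(NC(=O)Nc2cnc3ccccc3n2)n1` reaches only a limit in this assay, > 10000 nM (the limit of > 10000 nM in this assay, at which 1 of the 3 values shown sits). The change from compound 1 to compound 3, (hydroxy in place of hydrogen on a saturated chain carbon, two bonds along the chain from an aromatic nitrogen), made an at least 2.0-fold higher number from compound 1 to compound 3 (0.31 log units; beyond the scatter). Compound 4 `C[C@H](CO)n1cnnc1-c1cccc(NC(=O)Nc2ncc3ccccc3n2)n1` applies the same change to the core of compound 2: hydroxy in place of hydrogen on a saturated chain carbon, two bonds along the chain from an aromatic nitrogen. The step in this assay is expected to be of similar size or larger, resting on an at least 2.0-fold higher number from compound 1 to compound 3 (0.31 log units; beyond the scatter), which is itself only bounded by the limit. Compound 4 is estimated at 7000 nM in this assay, an expected step of a 2.4-fold higher number from compound 2 to compound 4 (0.38 log units; beyond the scatter).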

Compound 4, half-maximal inhibitory concentration: 7170 nM
The estimate for compound 4 lay 1.0-fold (0.01 log units) below the measured number, and the stated range covers the measured number.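

In this assay, hydroxy in place of hydrogen on a saturated chain carbon, two bonds along the chain from an aromatic nitrogen, gives a 2.5-fold higher number from compound 2 to compound 4 (0.39 log units; beyond the scatter), so the direction seen on the core of compound 1 carries over to the core of compound 2. Set side by side, the two steps read: the same change on two cores in this assay, an at least 2.0-fold higher number (0.31 log units; beyond the scatter) from compound 1 to compound 3 and a 2.5-fold higher number (0.39 log units; beyond the scatter) from compound 2 to compound 4; the limit leaves it open whether they differ. Compound 3 stands at a limit of the assay, > 10000 nM, so the size of its step is not known and equal size on the two cores is not shown.

The compounds shown leave open whether a methoxy, an amine or a carboxylic acid in place of the hydroxy would behave the same way on either core. On these data alone, a longer chain carrying the hydroxy also remains open.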